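The source may report more compounds than this note shows. Statements on the series, on what has been measured and on what is new or still open speak of the compounds shown alone.

Measured so far in a functional assay on A549 cells (Homo sapiens) for inhibition, read by CCK-8 assay, with a stated time of 48 h; on this read-out higher numbers stand for weaker inhibition and lower numbers for stronger inhibition:
- Compound 1 `COc1cc(-c2ccnc3cc(-c4cn(C)c5ccccc45)nn23)cc(OC)c1OC`: 1340 nM
- Compound 2 `COc1ccc(-c2cc3nccc(-c4cc(OC)c(OC)c(OC)c4)n3n2)cc1F`: 545 nM

Compound 2 has the lower of these two numbers, and its gap to compound 1 lies beyond the usual scatter. The next compound, compound 3 `COc1ccc(-c2cc3nccc(-c4cc(OC)c(OC)c(OC)c4)n3n2)cc1N`, differs from compound 2 in one group: amino in place of fluoro on an aromatic carbon. Amino takes the place of fluoro on an aromatic carbon, ortho to a methoxy group, so 3-fluoro-4-methoxyphenyl becomes 3-amino-4-methoxyphenyl.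

For the measured compounds named here, only one measured step offers any guide: a 2.5-fold lower number from compound 1 to compound 2 (0.39 log units; beyond the scatter). This modest step came from exchanging 1-methyl-1H-indol-3-yl for 3-fluoro-4-methoxyphenyl. Going by the values given here, it gives a rough idea of the size of change seen so far, but no measured pair compares amino with fluoro, so the direction remains uncertain. In this assay, a similarly modest change is expected, with a tentative lean towards a lower number. The expected change is a 2.2-fold lower number from compound 2 to compound 3 (0.34 log units; beyond the scatter). For compound 3, the estimated value is 250 nM, with an expected range of 50 nM to 1000 nM.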

Compound 3, half-maximal inhibitory concentration: 138 nM
Estimate against measurement, compound 3: 1.8-fold (0.26 log units) above, within the range that was stated.
By their numbers in this assay, from the lowest: compound 3; then compound 2; then compound 1.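

In this assay, amino in place of fluoro on an aromatic carbon, ortho to a methoxy group, gives a 3.9-fold lower number from compound 2 to compound 3 (0.60 log units; beyond the scatter), so this position responds to the exchange of one heavy atom for another and the choice of group here matters. Measured against the indole-bearing compound, the 3-amino-4-methoxyphenyl group gives a 9.7-fold lower number from compound 1 to compound 3 (0.99 log units; beyond the scatter), which leaves compound 3 with the lowest number of the three, and its steps to both other compounds lie beyond the scatter. Amino brings one hydrogen-bond donor and one hydrogen-bond acceptor where fluoro counts none, but nothing measured here tells what lies behind the step.

The compounds shown leave open whether the step belongs to amino in particular, since a hydroxyl, a methylamino or an acetamide group at the same position would be needed to test that. They also leave open whether amino would give a similar step with ethoxy in place of the methoxy group, or with the amino group placed elsewhere on the same ring.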